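The source may hold more compounds than are shown below. What is called first, only, known or untested is meant among the compounds shown, and "the series" means these compounds.

Measured compounds:
Compound 1, `COc1ccc(CNc2ncnc3c2ncn3C2CCCCO2)c(OC)c1`: in an ADME assay on K562 cells (Homo sapiens) for cytotoxicity, with a stated time of 72 h (a lower number here means a stronger inhibitor, a higher number a weaker inhibitor), compound 1 gives > 25000 nM, which is a limit of the assay.
Compound 2, `COc1ccc(CNc2ncnc3c2ncn3C2CCCCO2)c(OC)c1OC`: in this assay compound 2 gives > 37500 nM, also a limit.
Compound 3, `COc1cc(OC)c(OC)cc1CNc1ncnc2c1ncn2C1CCCCO1`: in this assay compound 3 gives > 100000 nM, again a limit.

Compound 1 therefore stands only at a limit, and the two other compounds do too, so no order among them can be read. Compound 4, `COc1ccc(CNc2ncnc3c2ncn3C2CCCO2)c(OC)c1`, differs from compound 1 by oxolan-2-yl in place of oxan-2-yl on an aromatic nitrogen. The measured steps that start from compound 1, a step that the two limits leave unreadable from compound 1 to compound 2 and a step that the two limits leave unreadable from compound 1 to compound 3, alter a different part of the molecule and their size cannot be read because both ends sit at a limit (the limit of > 25000 nM in this assay, at which 1 of the 3 values shown sits), the limit of > 37500 nM in this assay, at which 1 of the 3 values shown sits, and (the limit of > 100000 nM in this assay, at which 1 of the 3 values shown sits). Within the data shown here, no measured step touches the ring on the aromatic nitrogen. Compound 4 is expected to remain near the limit, with an estimate of 30000 nM in this assay, ranging from 8000 nM to 100000 nM. This amounts to an expected step that the limit leaves unreadable from compound 1 to compound 4, nothing beyond the scatter.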

Compound 4, half-maximal inhibitory concentration: > 100000 nM
Compound 4 was reported as a limit; the forecaster's own chance of this, stated with the estimate: 75%; middle value at least 3.3-fold (0.52 log units) from the limit.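

Compound 1 and compound 4 both stand only at limits, so the step from oxan-2-yl to oxolan-2-yl cannot be read. The compounds shown leave open how any of the four ranks against the others.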